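Shortening the Chain of Compound 1

This account rests on a few compounds, and the source may have more. Where it says the series, first, only, none or still open, it means among the compounds named here.

Compound 1 `CCCCCCCCCCCCCC(=O)c1c(O)cc(C)oc1=O`: > 200000 nM
Compound 2 `Cc1cc(O)c(C(=O)C2CCCCC2)c(=O)o1`: > 200000 nM

Both entries come from an ADME assay on L929 cells (Mus musculus, culture collection number NCTC 929) for cytotoxicity, read by MTT assay, with a stated time of 72 h (a lower number here means a stronger inhibitor, a higher number a weaker inhibitor), and neither is a true number. In this assay compound 1 gives > 200000 nM, which is a limit of the assay. Compound 2 gives > 200000 nM, which is also a limit. Compound 1 therefore stands at the limit of > 200000 nM in this assay, at which 2 of the 2 values shown sit.

The next compound to be tested is compound 3 `CCCCCCCC(=O)c1c(O)cc(C)oc1=O`, which has a shorter chain than compound 1. The change is hydrogen in place of hexyl on a saturated chain carbon, seven bonds along the chain from a carbonyl carbon. Put another way, heptyl gives way to methyl.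

For the measured compounds named here, no two measured compounds differ in just one place, so no measured step shows what such a change does in this assay. Compound 1 gives only a limit, > 200000 nM, so the starting point is not an exact number. The expected result is no change beyond the scatter, in either direction, and compound 3 may well be reported only as a limit too. The expected size of the change is a number no higher from compound 1 to compound 3 (the limit leaves the size open). For compound 3 the estimated value is 200000 nM, with an expected range from 80000 nM to 400000 nM.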

Compound 3, half-maximal inhibitory concentration: 140000 nM
Compound 3: the middle estimate sits 1.4-fold (0.15 log units) above what was measured; measured number inside the range.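

Replacing hexyl with hydrogen on a saturated chain carbon, seven bonds along the chain from a carbonyl carbon, gives an at least 1.4-fold lower number from compound 1 to compound 3 (0.15 log units; that floor lies within the scatter) in this assay. For the compounds shown here, compound 3 is the first compound here to give a true number rather than a limit, so this shortened chain brings the result within the range that the assay can report. Compound 1 gives > 200000 nM, which is a limit, so the printed step marks only the smallest size the change can have, and the real difference between the two compounds cannot be read exactly.

A still shorter chain, or a chain carrying an amine or a carboxylic acid, might or might not give a number clearly lower than that of compound 3, and nothing shown here settles whether chain length drives a real trend on the shared core. Most of the small set still gives no exact number for such comparisons: the limit of > 200000 nM in this assay, at which 2 of the 3 values shown sit.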